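Moving a Methyl Branch: Solubility Expected for Compound 4

The source may report more compounds than this note shows. Statements on the series, on what has been measured and on what is new or still open speak of the compounds shown alone.

Compound 1 `O=c1nc(N2CCN(CC3CCCCC3)CC2)sc2c([N+](=O)[O-])cc(C(F)(F)F)cc12`: 9.07 ug/mL
Compound 2 `O=C(c1ccccc1F)N1CCN(c2nc(=O)c3cc(C(F)(F)F)cc([N+](=O)[O-])c3s2)CC1`: 3.1 ug/mL
Compound 3 `CCC(C)C(=O)N1CCN(c2nc(=O)c3cc(C(F)(F)F)cc([N+](=O)[O-])c3s2)CC1`: 104 ug/mL

In a physicochemical assay for solubility, read by HPLC (on this read-out higher numbers stand for higher solubility and lower numbers for lower solubility), compound 3 stands highest of the three numbers shown. The two steps that reach it are both beyond the scatter: an 11-fold higher number from compound 1 to compound 3 (1.06 log units; beyond the scatter) and a 34-fold higher number from compound 2 to compound 3 (1.53 log units; beyond the scatter). The third measured step, a 2.9-fold lower number from compound 1 to compound 2 (0.47 log units; beyond the scatter), lies between the two lower compounds and does not touch compound 3.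

Compound 4 `CC(C)CC(=O)N1CCN(c2nc(=O)c3cc(C(F)(F)F)cc([N+](=O)[O-])c3s2)CC1` differs from compound 3 in one place: isobutyl in place of sec-butyl on a carbonyl carbon. The two compounds hold the same atoms, joined differently. Within the data shown here, no measured step exchanges one saturated four-carbon chain for another; the steps that bear on compound 3, an 11-fold higher number from compound 1 to compound 3 (1.06 log units; beyond the scatter) and a 34-fold higher number from compound 2 to compound 3 (1.53 log units; beyond the scatter), exchange groups of quite another kind and so fix where compound 3 stands rather than the size of this move. For a change this small, the step is expected to stay within the scatter, with the number for compound 4 a little under that of compound 3: a 1.3-fold lower number from compound 3 to compound 4 (0.11 log units; within the scatter). Compound 4 is therefore estimated at 80 ug/mL, with a range from 35 ug/mL to 200 ug/mL.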

Compound 4, solubility: 66.3 ug/mL
Estimate against measurement, compound 4: 1.2-fold (0.08 log units) above; the measured number falls inside the stated range.
By their numbers in this assay, from the lowest: compound 2; then compound 1; then compounds 4 and 3 (each within the scatter of the next).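

In this assay, moving the methyl branch along the chain on the carbonyl carbon gives a 1.6-fold lower number from compound 3 to compound 4 (0.20 log units; within the scatter), so at this position sec-butyl and isobutyl cannot be told apart. The large difference from the 2-fluorophenyl amide holds with the new chain, as a 21-fold higher number from compound 2 to compound 4 (1.33 log units; beyond the scatter), and isobutylcarbonyl also stands clear of cyclohexylmethyl, with a 7.3-fold higher number from compound 1 to compound 4 (0.86 log units; beyond the scatter); among these four compounds, both saturated four-carbon acyl groups therefore read above the other two groups, and no compound goes against this. Nothing measured here accounts for these differences.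

The compounds shown leave open whether a longer chain, a straight butyl chain or a cyclohexyl group on the same carbonyl carbon would stay with compound 3 and compound 4. They also leave open what an amine or a carboxylic acid at the end of such a chain would do.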